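Urea-substituted quinolone series: nitro removal in antiproliferative assay

The source may report more compounds than this note shows. Statements on the series, on what has been measured and on what is new or still open speak of the compounds shown alone.

Measured compounds:
- compound 1, `COc1ccc(-c2cc(=O)c3c(OC)cc(OC)cc3n2S(=O)(=O)c2ccc(Cl)cc2)cc1`: "not determined" (no result reported) in a functional assay on SEM cells (Homo sapiens) for antiproliferative activity, with a stated time of 72 h (a higher number here means that more compound is needed for the effect, a lower number that less compound is needed), so no result is reported
- compound 2, `COC(=O)c1cc(=O)c2cc(NC(=O)Nc3ccc(C(F)(F)F)cc3[N+](=O)[O-])ccc2[nH]1`: 22500 nM

Within the data shown here, compound 2 carries the only number in this assay; compound 1 has no number there, so no comparison between the two is possible. Compound 3, `COC(=O)c1cc(=O)c2cc(NC(=O)Nc3ccc(C(F)(F)F)cc3)ccc2[nH]1`, is yet to be tested. The change from compound 2 to compound 3 is hydrogen in place of nitro on an aromatic carbon of the aryl urea.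

Among the measured compounds shown here, no step between measured compounds is available, so the size of this step cannot be read from the series. With only compound 2 as anchor, the expectation is a step of a 1.3-fold higher number from compound 2 to compound 3 (0.12 log units; within the scatter), a small shift toward needing more compound that may well sit within the usual scatter. Compound 3 is therefore estimated at 30000 nM, with a range from 8000 nM to 100000 nM.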

Compound 3, half-maximal effective concentration: > 6350 nM
Compound 3 ended at the assay's limit (the forecaster's own chance of this, stated with the estimate: 25%); the middle value lies beyond the limit too.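

Among these compounds, compound 3 gives > 6350 nM in this assay; this value is a limit of the assay, so no step from compound 2 to compound 3 can be read. From the compounds shown here alone, whether hydrogen in place of nitro changes the result in this assay, and by how much, stays open.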